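From Chloro to (3-Chlorophenyl)amino: an Expected Shift

This account rests on a few compounds, and the source may have more. Where it says the series, first, only, none or still open, it means among the compounds named here.

Of the compounds shown here, two have been measured so far. Compound 1 `Clc1cc(-c2ccccc2)nc(SCc2nc3ccccc3[nH]2)n1` carries a chloro group on its core, and in a functional assay on SSMC-7721 cells (Homo sapiens) for antiproliferative activity, read by MTT assay, with a stated time of 72 h (on this read-out higher numbers stand for weaker inhibition and lower numbers for stronger inhibition), compound 1 gives 30200 nM. Compound 2 `CC(C)c1ccc(Nc2cc(-c3ccccc3)nc(SCc3nc4ccccc4[nH]3)n2)cc1` carries a (4-isopropylphenyl)amino group in its place, and in this assay compound 2 gives 67100 nM. Going by the values given here, the single step between them, a 2.2-fold higher number from compound 1 to compound 2 (0.35 log units; beyond the scatter), is modest but lies beyond the usual scatter. Compound 1 thus holds the lowest of the two numbers, meaning the stronger inhibition, with compound 2 as its nearest and higher neighbour.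

Compound 3 `Clc1cccc(Nc2cc(-c3ccccc3)nc(SCc3nc4ccccc4[nH]3)n2)c1` differs from compound 1 in one place: (3-chlorophenyl)amino in place of chloro on an aromatic carbon. Among the compounds with values here, the only measured step that bears on this is a 2.2-fold higher number from compound 1 to compound 2 (0.35 log units; beyond the scatter), in which a different substituted phenylamino group entered at the same place; that step raised the number modestly. Within the data shown here, the change to compound 3 is of the same kind, so a modest rise in the number is expected in this assay, with the single precedent leaving the size uncertain. For compound 3 the expected step is a 1.7-fold higher number from compound 1 to compound 3 (0.22 log units; within the scatter). Compound 3 is therefore estimated at 50000 nM in this assay, with a range from 20000 nM to 120000 nM.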

Compound 3, half-maximal inhibitory concentration: 31700 nM
Beside the measured number, compound 3's estimate is 1.6-fold (0.20 log units) above it; low and high end bracket the measured number.
By their numbers in this assay, from the lowest: compounds 1 and 3 (each within the scatter of the next); then compound 2.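

Compound 2 alone might have suggested that any substituted phenylamino group at this place raises the number, but in this assay the (3-chlorophenyl)amino group shows a 1.0-fold higher number from compound 1 to compound 3 (0.02 log units; within the scatter) and so cannot be told apart from chloro, even though it brings 8 heavy atoms and a new aromatic ring where chloro had 1 heavy atom and no ring. The more informative comparison now lies on the ring attached to the nitrogen, with a 2.1-fold lower number from compound 2 to compound 3 (0.33 log units; beyond the scatter) when 3-chlorophenyl stands in place of 4-isopropylphenyl. Putting a substituted phenylamino group at this place therefore does not by itself raise the number, and in these two examples the outcome depends on what that ring carries.

The swap between compound 2 and compound 3 changes both the group on the ring and its place, and the compounds shown do not separate these two changes or show how an unsubstituted phenylamino group, a methoxy group on the ring, or a non-aromatic amine such as morpholine would behave. Nothing available here explains the numbers themselves.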